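A few compounds are considered here, and "the series" means these few. Any claim that something is new, unique, unknown or untested is made for them only; others in the source may bear on it.

Working notes on the series in a functional assay on the whole organism (strain Jcl:SD) for inhibition, with Rattus norvegicus as the target, with stated times of 3 min and 3 h, at a dose of 1 mg/kg by the intravenous route; on this read-out higher numbers stand for more inhibition at the one dose given (going by the name of the read-out) and lower numbers for less inhibition. Compound 1 `CNCc1cc(-c2cccnc2F)n(S(=O)(=O)c2cccnc2)c1` gives 96%. Among the measured compounds shown here, compound 2 `CNCc1cc(-c2cccnc2C)n(S(=O)(=O)c2cccnc2)c1` gives -41%, and the single change of a number 137 percentage points lower from compound 1 to compound 2 (beyond the scatter) is the largest drop recorded here. Compound 3 `CNCc1cc(-c2ncccc2C)n(S(=O)(=O)c2cccnc2)c1` gives 5%; it stands second highest of the three numbers, nearest to compound 2 and furthest from compound 1, with a number 91 percentage points lower from compound 1 to compound 3 (beyond the scatter) and a number 46 percentage points higher from compound 2 to compound 3 (beyond the scatter) both beyond the scatter.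

Compound 4 `CNCc1cc(-c2ccncc2F)n(S(=O)(=O)c2cccnc2)c1` differs from compound 3 in one place: 3-fluoropyridin-4-yl in place of 3-methylpyridin-2-yl on an aromatic carbon. For the measured compounds named here, three measured steps bear on this exchange. The loss of fluoro for methyl cost heavily in a number 137 percentage points lower from compound 1 to compound 2 (beyond the scatter); the 2-fluoropyridin-3-yl to 3-methylpyridin-2-yl exchange cost almost as much in a number 91 percentage points lower from compound 1 to compound 3 (beyond the scatter); and the rearrangement between the two methylpyridinyl groups recovered part of it in a number 46 percentage points higher from compound 2 to compound 3 (beyond the scatter). Going by the values given here, compound 4 returns a fluoro substituent, which in this set accompanies the only high number, that of compound 1, but the 3-fluoropyridin-4-yl group itself has no precedent among the measured compounds, so the size of the effect is open.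

On balance an increase from compound 3 is expected, roughly a number 45 percentage points higher from compound 3 to compound 4 (beyond the scatter), and compound 4 is therefore estimated at 50%, within a wide range from 0% to 95%.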

Compound 4, a percentage reported as inhibition, in the whole organism at one dose (the size of the read-out at that dose, not a potency): 48%
Estimate against measurement, compound 4: 2 percentage points above; the measured number falls inside the stated range.
By their numbers in this assay, from the lowest: compound 2; then compound 3; then compound 4; then compound 1.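

In this assay, the 3-fluoropyridin-4-yl group at this aromatic carbon gives a number 43 percentage points higher from compound 3 to compound 4 (beyond the scatter) and a number 89 percentage points higher from compound 2 to compound 4 (beyond the scatter), so a high number here is not confined to the 2-fluoropyridin-3-yl group of compound 1. Fluoro on the pyridine does not by itself set the level, however: the exchange between the two fluoropyridinyl groups gives a number 48 percentage points lower from compound 1 to compound 4 (beyond the scatter), which shows that the choice of fluoropyridinyl group matters as well as the choice of fluoro over methyl. Across these four compounds, both fluoropyridinyl compounds stand above both methylpyridinyl compounds, and no compound here goes against that order.

Nothing at hand accounts for any of these differences. Still open, from the compounds shown here alone, are how a 2-fluorophenyl group, which carries no ring nitrogen, would stand at this position, how a chloro or methoxy substituent would compare with fluoro on the same pyridine, and whether 3-methylpyridin-4-yl would fall below compound 4 in the way that the methyl group of compound 2 falls below the fluoro group of compound 1.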